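Replacing the Thiophene Amide Cap with a Pyrimidinylamine

A few compounds are considered here, and "the series" means these few. Any claim that something is new, unique, unknown or untested is made for them only; others in the source may bear on it.

Compound 1 `CC(=O)N1CCC(C(=O)N(CCCN2CCC(CNC(=O)c3ccsc3)CC2)c2ccc(C)c(Cl)c2)CC1` gives > 51900 nM in an ADME assay (Homo sapiens) for cytotoxicity; a higher number here means that more compound is tolerated, a lower number that less compound is tolerated.
Compound 2 `CC(=O)N1CCC(C(=O)N(CCCN2CCN(Cc3cccnc3)CC2)c2ccc(C)c(Cl)c2)CC1` gives > 56700 nM in this assay.
Compound 3 `CC(=O)N1CCC(C(=O)N(CCCN2CCN(Cc3ccc(Cl)cc3)CC2)c2ccc(C)c(Cl)c2)CC1` gives 37600 nM in this assay.

The three measured compounds share one core and differ only in the group carried on the far end of the chain. For compound 1 the value is a limit of the assay, not a number, as shown by the limit of > 51900 nM in this assay, at which 1 of the 3 values shown sits. For compound 2 the value is likewise a limit, as shown by the limit of > 56700 nM in this assay, at which 1 of the 3 values shown sits. Compound 3 alone returns a measured number. For the measured compounds named here, the only step between single-point neighbours is an at least 1.5-fold lower number from compound 2 to compound 3 (0.17 log units; that floor lies within the scatter), and its floor lies within the scatter, so it shows no change that can be trusted.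

Compound 4 `CC(=O)N1CCC(C(=O)N(CCCN2CCC(CNc3ncccn3)CC2)c2ccc(C)c(Cl)c2)CC1` differs from compound 1 by pyrimidin-2-yl in place of (thiophen-3-yl)carbonyl on an amine nitrogen. Going by the values given here, no measured step touches this amine nitrogen; the one step recorded changes a different group at a different place and is itself within the scatter. With compound 1 standing at a limit and nothing in the data pointing one way or the other, the expected step of an at least 1.0-fold lower number from compound 1 to compound 4 (0.01 log units; that floor lies within the scatter) is none beyond the scatter, and a second limit is quite possible. Compound 4 is therefore estimated at 50000 nM, with a range from 20000 nM to 110000 nM.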

Compound 4, half-maximal cytotoxic concentration: > 55100 nM
Compound 4: only a limit was reported (the forecaster's own chance of this, stated with the estimate: 60%); middle value at least 1.1-fold (0.04 log units) away from the limit.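

In this assay compound 4 gives a limit and not a number, > 55100 nM. For the compounds shown here, compound 1 also gives a limit, > 51900 nM, so no step between compound 1 and compound 4 can be read. The compounds shown leave open whether pyrimidin-2-yl in place of (thiophen-3-yl)carbonyl on an amine nitrogen changes the number in this assay at all.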